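Benzyl for hydrogen on a hydroxy of compound 3

A few compounds are considered here, and "the series" means these few. Any claim that something is new, unique, unknown or untested is made for them only; others in the source may bear on it.

Compound 1 `CC(=O)OC[C@@H]1O[C@H](COCc2ccccc2)[C@@H](OCc2ccccc2)[C@H](OCc2ccccc2)[C@H]1OC(C)=O` gives "not active" (no number reported) in a functional assay on HL-60 cells (Homo sapiens) for antiproliferative activity, read by MTT assay; a higher number here means a weaker inhibitor, a lower number a stronger inhibitor.
Compound 2 `OC[C@H]1O[C@@H](Cc2ccccc2)[C@H](O)[C@@H](OCc2ccccc2)[C@@H]1OCc1ccccc1` gives 20200 nM in this assay.
Compound 3 `O[C@@H]1[C@@H](O)[C@H](Cc2ccccc2)O[C@H](COCc2ccccc2)[C@H]1O` gives "not active" (no number reported) in this assay.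

Compound 3 stands without a single number in this assay, as does compound 1; only compound 2 has a number, and that one is weak. Compound 4 `O[C@@H]1[C@@H](OCc2ccccc2)[C@H](O)[C@@H](COCc2ccccc2)O[C@H]1Cc1ccccc1` differs from compound 3 by benzyl in place of hydrogen on an oxygen on a saturated carbon. With that benzyl, compound 4 comes nearer to compound 2, which carries more benzyl groups than compound 3 and does show a number. He therefore expects a shift toward lower numbers in this assay for compound 4, possibly beyond the scatter, though a further report of no number is likely. His estimate for compound 4 is 35000 nM, within 10000 nM to 120000 nM.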

Compound 4, half-maximal inhibitory concentration: 35300 nM
The estimate for compound 4 lay 1.0-fold (0.00 log units) below the measured number; the range from low to high includes it.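

Going by these compounds alone, compound 3 has no number in this assay, and no step from it to compound 4 can be read. The compounds shown leave open how far benzyl on that oxygen moves the activity. No evidence given here bears on this result.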